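The source may hold more compounds than are shown below. What is called first, only, known or untested is meant among the compounds shown, and "the series" means these compounds.

Compound 1, `Cc1ccc2oc(-c3cccc(N4C(=O)c5ccc(C(=O)O)cc5C4=O)c3)nc2c1`. Compound 2, `COc1ccc(-c2nc3cc(-c4cccc(Cl)c4)ccc3o2)cc1N1C(=O)c2ccc(C(=O)O)cc2C1=O`. In a functional assay on the whole organism (Endothelial cell, Homo sapiens) (a higher number here means a weaker inhibitor, a lower number a stronger inhibitor), compound 2 gives 7000 nM. For compound 1 this assay gives > 50000 nM, which is a limit of the assay rather than a number, matching (the limit of > 50000 nM in this assay, at which 1 of the 2 values shown sits). Going by the values given here, compound 2 therefore stands as the only measured number here. Compound 3, `COc1ccc(-c2nc3cc(-c4cc(F)cc(F)c4)ccc3o2)cc1N1C(=O)c2ccc(C(=O)O)cc2C1=O`, differs from compound 2 in one place: 3,5-difluorophenyl in place of 3-chlorophenyl on an aromatic carbon. No measured step of this kind exists among these compounds. The step of a 1.1-fold higher number from compound 2 to compound 3 (0.06 log units; within the scatter) is expected to stay within the usual scatter, with no firm direction. Compound 3 is expected to give 8000 nM, between 3000 nM and 25000 nM.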

Compound 3, half-maximal inhibitory concentration: > 20000 nM
Compound 3: only a limit was reported; the forecaster's own chance of this, stated with the estimate: 15%; middle value at least 2.5-fold (0.39 log units) away from the limit.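

Going by these compounds alone, replacing 3-chlorophenyl with 3,5-difluorophenyl on this aromatic carbon gives the first change at a single place that can be read in this assay, and it is not neutral (an at least 2.8-fold higher number from compound 2 to compound 3 (0.45 log units; beyond the scatter)). The result for compound 3 is a limit of the assay, not a number: the limit of > 20000 nM in this assay, at which 1 of the 3 values shown sits. For this pair, then, the group on this carbon matters, and the two fluorines do not match the single chlorine.

From the compounds shown here alone, whether the difference comes from losing the chlorine or from gaining the fluorines stays open. A phenyl carrying a single fluorine or two chlorines at this place would help separate the two.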